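The source may report more compounds than this note shows. Statements on the series, on what has been measured and on what is new or still open speak of the compounds shown alone.

Measured so far in a functional assay on U-251 cells (Homo sapiens); a higher number here means a weaker inhibitor of growth, a lower number a stronger inhibitor of growth:
Compound 1 `N#Cc1ccc(/C=C/S(=O)(=O)Cc2ccc(Nc3ncnc4ccccc34)cc2)cc1`: > 100000 nM
Compound 2 `O=S(=O)(/C=C/c1ccc(Br)cc1)Cc1ccc(Nc2ncnc3ccccc23)cc1`: > 100000 nM
Compound 3 `CC(C)(C)c1cc(/C=C/S(=O)(=O)Cc2ccc(Nc3ncnc4ccccc34)cc2)cc(C(C)(C)C)c1O`: 38000 nM

Compound 1 stands at > 100000 nM, which is a limit of the assay and not a number. Compound 2 shares this position, so the picture so far is the limit of > 100000 nM in this assay, at which 2 of the 3 values shown sit. Only compound 3 gives a true number, 38000 nM.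

Compound 4 `O=S(=O)(/C=C/c1ccc(Cl)cc1Cl)Cc1ccc(Nc2ncnc3ccccc23)cc1` keeps the core of compound 1 and changes one group: 2,4-dichlorophenyl in place of 4-cyanophenyl on a double-bonded chain carbon bound to a double-bonded chain carbon. The nitrile leaves with the 4-cyanophenyl group, and two chlorines enter with the 2,4-dichlorophenyl group.

The nearest measured change is a step that the two limits leave unreadable from compound 1 to compound 2. It also removes the cyano group, but it offers no size to carry forward. Compound 2, which carries bromo instead, still reads > 100000 nM, and that limit suggests compound 4 may well stay in the same region of this assay. The expected result is a number no higher from compound 1 to compound 4 (the limit leaves the size open), an estimate with no firm direction. For compound 4 the estimated value is 100000 nM, with an expected range from 40000 nM to 200000 nM.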

Compound 4, concentration for 50% growth inhibition: 4000 nM
The estimate for compound 4 lay 25-fold (1.40 log units) above the measured number, outside the stated range (below it).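

In this assay, putting 2,4-dichlorophenyl in place of 4-cyanophenyl on a double-bonded chain carbon bound to a double-bonded chain carbon gives an at least 25-fold lower number from compound 1 to compound 4 (1.39 log units; beyond the scatter), the first readable size for a change at this position. Putting 2,4-dichlorophenyl in place of 4-bromophenyl at the same position gives an at least 25-fold lower number from compound 2 to compound 4 (1.39 log units; beyond the scatter), so the group held at the end of this chain can clearly separate compounds that share the core of compound 1, and a single bromo group at that ring does not give the same result as the two chlorines. The earlier compounds could not show this, with compound 1 and compound 2 each resting on a limit of the assay and not on a number: the limit of > 100000 nM in this assay, at which 2 of the 4 values shown sit.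

The compounds shown leave open whether both chlorines of the 2,4-dichlorophenyl group are needed or whether a single chlorine on the phenyl ring would read the same in this assay. They also leave open how a phenyl ring carrying an amine or a carboxylic acid would read at this position.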